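A few compounds are considered here, and "the series" means these few. Any claim that something is new, unique, unknown or untested is made for them only; others in the source may bear on it.

In a functional assay on NCI-H226 cells (Homo sapiens) for inhibition, read by MTT assay, with a stated time of 72 h (on this read-out lower numbers stand for stronger inhibition of growth and higher numbers for weaker inhibition of growth), the measured compounds stand as follows:

compound 1 `COC(=O)c1nc(C)n(-c2ccccc2)n1`: > 100000 nM, a limit of the assay
compound 2 `COC(=O)c1nc(C)n(-c2ccc(C(F)(F)F)cc2)n1`: 16600 nM

For the measured compounds named here, compound 2 gives the only number in this assay; the value for compound 1 is a limit (the limit of > 100000 nM in this assay, at which 1 of the 2 values shown sits). Going by the values given here, the single measured step, an at least 6.0-fold lower number from compound 1 to compound 2 (0.77 log units; beyond the scatter), concerns the trifluoromethyl in place of hydrogen. Compound 3 `COC(=O)c1nc(-c2ccoc2)n(-c2ccc(C(F)(F)F)cc2)n1` differs from compound 2 elsewhere: furan-3-yl in place of methyl on an aromatic carbon. No measured step touches the methyl, so the change from compound 2 to compound 3 has no precedent among these compounds, and the trifluoromethyl step offers no guide to its size or direction. Only a loose expectation is therefore possible. Compound 3 is estimated at 9000 nM in this assay, with a range from 1500 nM to 50000 nM. That estimate means an expected step of a 1.8-fold lower number from compound 2 to compound 3 (0.27 log units; within the scatter), which may well remain within the scatter.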

Compound 3, concentration for 50% growth inhibition: 6010 nM
Compound 3: the middle estimate sits 1.5-fold (0.18 log units) above what was measured; the range from low to high includes it.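

For the compounds shown here, the position between two ring nitrogen atoms, which no earlier step had touched, proves responsive: in this assay, furan-3-yl in place of methyl gives a 2.8-fold lower number from compound 2 to compound 3 (0.44 log units; beyond the scatter). This step is modest but beyond the scatter, so a five-membered aromatic ring with 1 hetero atom is accepted here without any loss against methyl. Both steps shown now lower the number, each at a different place on the shared core, and neither compound goes against this.

As far as these compounds go, whether a phenyl ring, a furan-2-yl group or an amine at this position would do the same stays open, as does the effect of a carboxylic acid in place of the methoxycarbonyl group. The full size of the trifluoromethyl step also stays open, since that step rests on a limit: the limit of > 100000 nM in this assay, at which 1 of the 3 values shown sits.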